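Metabolic stability notes: substitution on the ring nitrogen

This account rests on a few compounds, and the source may have more. Where it says the series, first, only, none or still open, it means among the compounds named here.

Compound 1 `CCOC(=O)c1cccc(NC(=O)[C@@H]2C[C@H](SC3=C(C(=O)O)N4C(=O)[C@H]([C@@H](C)O)[C@H]4[C@H]3C)CN2)c1` and compound 2 `CCOC(=O)C1=C(S[C@@H]2CN[C@H](C(=O)Nc3cccc(C(=O)OCC)c3)C2)[C@H](C)[C@@H]2[C@@H]([C@@H](C)O)C(=O)N12` share one core, and compound 3 `CCOC(=O)C1=C(S[C@H]2C[C@@H](C(=O)Nc3cccc(C(=O)OCC)c3)N(Cc3oc(=O)oc3C)C2)[C@H](C)[C@@H]2[C@@H]([C@@H](C)O)C(=O)N12` extends compound 2. In an ADME assay for metabolic stability, read by LC-MS, with a stated time of 3 h, at pH 6.5, tested at 50 uM (on this read-out higher numbers stand for a more stable compound and lower numbers for a less stable compound), compound 1 gives > 95%, which is a limit of the assay rather than a number. In this assay compound 2 gives > 95%, likewise a limit of the assay. For the measured compounds named here, compound 2 thus stands only at a limit, and the one further value shown is a limit as well; both rest on (the limit of > 95% in this assay, at which 2 of the 2 values shown sit). Ethyl in place of hydrogen on an oxygen next to a carbonyl group yields a step that the two limits leave unreadable from compound 1 to compound 2, unreadable because both ends sit at the limit of > 95% in this assay, at which 2 of the 2 values shown sit.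

Compound 3 differs from compound 2 by a group of 8 heavy atoms (5 carbon, 3 oxygen; one five-membered aromatic ring with 2 hetero atoms) in place of a hydrogen atom, on an amine nitrogen in a ring. Going by the values given here, no measured step bears on this change, so no direction or size can be drawn from the measured pair. For compound 3 the step is estimated as a number at least 10 percentage points lower from compound 2 to compound 3 (that floor lies within the scatter), allowing that the value may fall off the limit. In this assay compound 3 is expected to give 85%. The expected range for compound 3 runs from 55% to 97%.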

Compound 3, percent of the compound remaining: > 95%
Compound 3 was reported as a limit; the forecaster's own chance of this, stated with the estimate: 40%; at least 10 percentage points between middle value and limit.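

In this assay compound 3 gives > 95%, a limit of the assay and not a number, so no step can be read from compound 2 to compound 3: the limit of > 95% in this assay, at which 3 of the 3 values shown sit.

The compounds shown leave open whether either change, the ethyl on the oxygen or the group on the amine nitrogen, alters the percent of compound remaining, and how compound 1, compound 2 and compound 3 would rank.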